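The source may hold more compounds than are shown below. What is called first, only, known or untested is meant among the compounds shown, and "the series" means these compounds.

Working notes on the series.

Compound 1 `COC(=O)c1sc2nc(C)ccc2c1Nc1cc(OC)c(OC)c(OC)c1`, compound 2 `COC(=O)c1sc2ncccc2c1Nc1cc(OC)c(OC)c(OC)c1` and compound 3 `COC(=O)c1sc2ccccc2c1Nc1cc(OC)c(OC)c(OC)c1` have been run in a functional assay on Jurkat cells (Homo sapiens) for cytotoxicity, read by MTT assay, with a stated time of 72 h; on this read-out higher numbers stand for weaker inhibition and lower numbers for stronger inhibition. Compound 1 gives 0.6 nM, compound 2 gives 1110 nM and compound 3 gives 490 nM. The change from compound 2 to compound 1, (methyl in place of hydrogen on an aromatic carbon), made a large step: a 1900-fold lower number from compound 2 to compound 1 (3.27 log units; beyond the scatter). The difference between the cores of compound 2 and compound 3 is not broken down here.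

Compound 4 `COC(=O)c1sc2cccc(C)c2c1Nc1cc(OC)c(OC)c(OC)c1` is not yet measured in this assay. It carries the same kind of change relative to compound 3, (methyl in place of hydrogen on an aromatic carbon), but the place is not the same: in compound 1 the methyl sits on a six-membered aromatic ring with one nitrogen, next to the ring nitrogen, meta and para to a fused ring, whereas in compound 4 it sits on a ring of carbon only, ortho and meta to a fused ring. Among the measured compounds shown here, with only one measured instance of this kind of change, and that at a different place, a smaller step than a 1900-fold lower number from compound 2 to compound 1 (3.27 log units; beyond the scatter) is expected, and the expected step for compound 4 is a 3.3-fold lower number from compound 3 to compound 4 (0.51 log units; beyond the scatter). Compound 4 is estimated at 150 nM, with a wide range from 20 nM to 1000 nM.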

Compound 4, half-maximal inhibitory concentration: 6710 nM
For compound 4 the middle estimate is 45-fold (1.65 log units) below the measured one, and the stated range ends below it.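

In this assay, methyl in place of hydrogen on the ring of carbon only gives a 14-fold higher number from compound 3 to compound 4 (1.14 log units; beyond the scatter), so the change does not carry a lower number over to this core. The two steps differ in direction and size: the same change on two cores in this assay, a 1900-fold lower number (3.27 log units; beyond the scatter) from compound 2 to compound 1 and a 14-fold higher number (1.14 log units; beyond the scatter) from compound 3 to compound 4, 25000-fold (4.40 log units) apart, beyond the scatter of two such steps. This shows that the step seen on the core of compound 2 cannot be transferred to the core of compound 3, but it does not separate the effect of the core from that of the methyl's place, as these differ together and each rests on a single pair.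

Open, on these data alone, is how a methyl at other places on either core would read. Also open, as far as these compounds go, is how an ethyl or an amine would read in place of the methyl.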